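The source may hold more compounds than are shown below. What is called first, only, known or untested is meant among the compounds shown, and "the series" means these compounds.

Among the compounds with values here, in a functional assay on cells (T-cell, Homo sapiens) for inhibition (a lower number here means a stronger inhibitor, a higher number a weaker inhibitor), compound 1 `COc1ccc(-c2cnc3nc(N)nc(N4CCN(C(=O)Nc5ccc(C)cc5)CC4)c3n2)cc1OC` gives 0.8 nM, the lowest of the three numbers measured so far. Its nearest neighbour, compound 2 `COc1ccc(-c2cnc3nc(N)nc(NC(C)C)c3n2)cc1OC`, gives 600 nM in this assay, a gap well beyond the scatter, and compound 3 `CCOc1nc(N)nc2ncc(-c3cccc(OC)c3)nc12` gives 8300 nM, further away still. Within the data shown here, both differ from compound 1 in more than one place, so no single step between measured compounds can be read from them.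

Compound 4 `COc1ccc(-c2cnc3nc(N)nc(N4CCN(C(=O)Nc5ccccc5)CC4)c3n2)cc1OC` has not yet been measured. It differs from compound 1 only at the phenylcarbamoyl end: hydrogen in place of methyl on an aromatic carbon so that the 4-methylphenyl becomes plain phenyl. Among the measured compounds shown here, no measured pair isolates such a change, so the expectation rests on the modest size of the change alone, a methyl lost from the outer edge of a large molecule. The expected step is small, a 1.5-fold higher number from compound 1 to compound 4 (0.18 log units; within the scatter), most likely within the scatter, with a slight loss if anything. Compound 4 is therefore expected to give 1.2 nM, with a range from 0.4 nM to 4 nM.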

Compound 4, half-maximal inhibitory concentration: 3.4 nM
Beside the measured number, compound 4's estimate is 2.8-fold (0.45 log units) below it, and the stated range covers the measured number.
By their numbers in this assay, from the lowest: compound 1; then compound 4; then compound 2; then compound 3.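

In this assay, hydrogen in place of methyl on an aromatic carbon gives a 4.3-fold higher number from compound 1 to compound 4 (0.63 log units; beyond the scatter), a modest step but one beyond the scatter. Within the data shown here, this is the first change that can be read at a single place, and it shows that the outer phenylcarbamoyl end of the molecule is not indifferent to the loss of one carbon: the 4-methylphenyl goes with the lower number here. Nothing available explains why this step occurs.

Still open, as far as these compounds go, is whether a different group at the same place, such as ethyl, chlorine or trifluoromethyl, would lower the number further or raise it. From the compounds shown here alone, it is also open whether a methyl elsewhere on this ring, or the same change on a different core, would give a step of similar size.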